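This account rests on a few compounds, and the source may have more. Where it says the series, first, only, none or still open, it means among the compounds named here.

Measured compounds:
compound 1, `CC(C)(C)C[C@@H](O)C(=O)N1[C@@H]2C[C@@H]2C[C@H]1C(=O)NCc1cc(Cl)ccc1-n1cnnn1`: in an ADME assay on liver for metabolic stability, with Liver microsome (Homo sapiens) as the target, read by LC-MS, using microsomes (a higher number here means faster removal of the compound, a lower number slower removal), compound 1 gives 71 mL.min-1.g-1
compound 2, `O=C(NCc1cc(Cl)ccc1-n1cnnn1)[C@@H]1[C@H]2C[C@H]2CN1C(=O)[C@H](O)Cc1ccccc1`: in this assay compound 2 gives 96 mL.min-1.g-1
compound 3, `O=C(NCc1cc(Cl)ccc1-n1cnnn1)[C@@H]1[C@@H]2C[C@@H]2CN1C(=O)[C@H](O)Cc1ccccc1`: in this assay compound 3 gives 74 mL.min-1.g-1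

Compound 3 stands second highest of the three numbers, but its gaps to compound 1 and to compound 2 both fall within the scatter, so the three compounds are not told apart by these data. Going by the values given here, the only measured step, a 1.3-fold lower number from compound 2 to compound 3 (0.11 log units; within the scatter), lies within the scatter as well and rests solely on (the fact that compounds 2 and 3 differ only in the configuration as drawn); it carries no information about an exchange of groups.

Compound 4, `COC(C)(C)[C@@H](O)C(=O)N1C[C@H]2C[C@H]2[C@H]1C(=O)NCc1cc(Cl)ccc1-n1cnnn1`, is reached from compound 3 by 1-methoxy-1-methylethyl in place of benzyl on a saturated chain carbon bound to a carbonyl carbon and an oxygen on a saturated carbon. Among the compounds with values here, no measured step bears directly on this exchange. What can be said is that the three measured values, across differing groups and configurations, all lie within the scatter of one another, giving no indication that this series moves much in this assay.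

The step from compound 3 to compound 4 is therefore expected to stay within the scatter, with no clear direction: a 1.1-fold lower number from compound 3 to compound 4 (0.02 log units; within the scatter). Compound 4 is estimated at 70 mL.min-1.g-1, with a range from 35 mL.min-1.g-1 to 140 mL.min-1.g-1.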

Compound 4, intrinsic clearance in microsomes: 23 mL.min-1.g-1
For compound 4 the middle estimate is 3.0-fold (0.48 log units) above the measured one; the whole stated range lies above it.
By their numbers in this assay, from the lowest: compound 4; then compounds 1, 3 and 2 (each within the scatter of the next).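

In this assay, the group on the saturated chain carbon bound to a carbonyl carbon and an oxygen on a saturated carbon proves able to move the number: 1-methoxy-1-methylethyl in place of benzyl gives the series its first step beyond the scatter (a 3.2-fold lower number from compound 3 to compound 4 (0.51 log units; beyond the scatter)). Going by these compounds alone, the only earlier step (a 1.3-fold lower number from compound 2 to compound 3 (0.11 log units; within the scatter)) stayed within the scatter and was a change of configuration as drawn, not of group. Nothing measured here gives a reason for the new step.

As far as these compounds go, the exchange removes the aromatic ring and adds a hydrogen-bond acceptor together, so it remains open which of the two carries the step; an isopropyl group in the same place on the core of compound 3 would separate them. From the compounds shown here alone, it is equally open whether the step holds on the core of compound 1.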